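Chloro in place of 1-methyl-1H-pyrazol-4-yl: compound 4

This account rests on a few compounds, and the source may have more. Where it says the series, first, only, none or still open, it means among the compounds named here.

Compound 2 `Cn1cc(-c2cncc(-c3ccc(C(N)=O)cc3)c2)cn1` holds the second highest of three numbers in an assay on cells for inhibition of MAP kinase-interacting serine/threonine-protein kinase 1 (Homo sapiens), read by mobility shift assay, with stated times of 10 min and 60 min, in the presence of a further agent that is not named here (a higher number here means a weaker inhibitor, a lower number a stronger inhibitor), giving 800 nM. Its nearest neighbour, compound 1 `CC(C)Oc1cc(-c2cncc(-c3cnn(C)c3)c2)ccc1C(N)=O`, gives 400 nM, and the step of a 2.0-fold higher number from compound 1 to compound 2 (0.30 log units; within the scatter) lies within the scatter. The furthest, compound 3 `COc1cc(-c2cccnc2)ccc1C(N)=O`, gives 2800 nM. Compound 4 `NC(=O)c1ccc(-c2cncc(Cl)c2)cc1` differs from compound 2 by chloro in place of 1-methyl-1H-pyrazol-4-yl on an aromatic carbon. Going by the values given here, no measured step matches this change: the one measured step concerns a different position, and compound 3 differs from compound 2 in two places, so its value shows only that a compound without the 1-methyl-1H-pyrazol-4-yl group gives a higher number. The step of a 3.8-fold higher number from compound 2 to compound 4 (0.57 log units; beyond the scatter) is therefore expected to raise the number beyond the scatter. Compound 4 is estimated at 3000 nM, within 1000 nM to 9000 nM.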

Compound 4, half-maximal inhibitory concentration: 14200 nM
Beside the measured number, compound 4's estimate is 4.7-fold (0.68 log units) below it, and the stated range ends below it.
By their numbers in this assay, from the lowest: compounds 1 and 2 (each within the scatter of the next); then compound 3; then compound 4.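

In this assay, going by these compounds alone, chloro in place of 1-methyl-1H-pyrazol-4-yl goes with an 18-fold higher number from compound 2 to compound 4 (1.25 log units; beyond the scatter), the only single change measured at this position. The one earlier step, a 2.0-fold higher number from compound 1 to compound 2 (0.30 log units; within the scatter), concerns another position, so this is the only single change shown to move the number beyond the scatter. Nothing measured here gives a reason for the size of this step. The compounds shown leave open whether the rise follows from the pyrazole leaving or from chloro entering, and whether methyl, an amine or phenyl on this carbon would keep the number near that of compound 2.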